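The source may hold more compounds than are shown below. What is called first, only, known or untested is meant among the compounds shown, and "the series" means these compounds.

Measured compounds and their values:

Compound 1, `CCCCCCCCCCn1cc(-c2nc3ccccc3cc2CCCC)nn1`, gives > 100 ug/mL in a functional assay on COLO 205 cells (Homo sapiens) for cytotoxicity, read by MTT assay, with a stated time of 24 h; a lower number here means a stronger inhibitor, a higher number a weaker inhibitor; this is a limit of the assay, not a number.
Compound 2, `CCCCCCCCCCn1cc(-c2nc3ccccc3cc2CCC)nn1`, gives > 100 ug/mL in this assay; this too is a limit.
Compound 3, `CCc1cc2ccccc2nc1-c1cn(-c2ccc(F)cc2)nn1`, gives > 100 ug/mL in this assay; again only a limit.

Compound 4, `CCCc1cc2ccccc2nc1-c1cn(-c2ccc(F)cc2)nn1`, has not yet been measured. It differs from compound 3 by one small change, (methyl in place of hydrogen on a saturated chain carbon, two bonds along the chain from an aromatic carbon). The same kind of change separates compound 2 from compound 1, (methyl in place of hydrogen on a saturated chain carbon, three bonds along the chain from an aromatic carbon), though the place is not identical: in that pair the added carbon sits three bonds along the chain from an aromatic carbon, whereas in compound 4 it sits two bonds along the chain from an aromatic carbon. The measured step that the two limits leave unreadable from compound 2 to compound 1 cannot be sized, since both ends of it are limits. How the core of compound 2 and the core of compound 3 differ is not broken down here. All that is known of the three measured compounds is the limit of > 100 ug/mL in this assay, at which 3 of the 3 values shown sit.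

On this slim basis, the step from compound 3 to compound 4 is expected to be a step that the limit leaves unreadable from compound 3 to compound 4, an expectation that rests on compound 2 and compound 1 giving a step that the two limits leave unreadable from compound 2 to compound 1 and on compound 3 giving > 100 ug/mL. Compound 4 is therefore estimated at 150 ug/mL, most likely reported only as a limit, with a plausible range from 50 ug/mL to 500 ug/mL.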

Compound 4, half-maximal inhibitory concentration: > 100 ug/mL
Compound 4 gave a limit, no number; the forecaster's own chance of this, stated with the estimate: 85%; the middle value lies beyond the limit too.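

In this assay compound 4 gives only a limit, as compound 3 does, so no step can be read between compound 3 and compound 4. The compounds shown leave open whether a longer chain changes the activity of any of them at all, and how their cores compare, because every result stops at one shared limit: the limit of > 100 ug/mL in this assay, at which 4 of the 4 values shown sit.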